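Adding a Methyl to the Phenyl Group of Compound 3

The source may hold more compounds than are shown below. What is called first, only, known or untested is meant among the compounds shown, and "the series" means these compounds.

Of the compounds shown here, three sharing one core have been tested in a functional assay on the whole organism for inhibition, with Mus musculus as the target, with a stated time of 4 h, at a dose of 50 mg/kg by the oral route; on this read-out lower numbers stand for less inhibition and higher numbers for more inhibition at the one dose given (going by the name of the read-out). Compound 1 `Cc1ccc(-c2c(S(=O)(=O)c3ccccc3)cnc3cc(C)nn23)cc1` gives 14%. Compound 2 `Cc1ccc(-c2c(S(=O)(=O)c3ccccc3)cnc3c(Br)c(-c4ccccc4)nn23)cc1` gives 12.5%. Compound 3 `Cc1ccc(-c2c(S(=O)(=O)c3ccccc3)cnc3cc(-c4ccccc4)nn23)cc1` gives 22.6%, the highest of the three numbers, although its gap to compound 1 lies within the scatter of this assay, so those two cannot be ranked against each other. The step of a number 8.6 percentage points higher from compound 1 to compound 3 (within the scatter) is small, while the step of a number 10.1 percentage points higher from compound 2 to compound 3 (beyond the scatter) just exceeds the scatter.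

Compound 4 `Cc1ccc(-c2cc3ncc(S(=O)(=O)c4ccccc4)c(-c4ccc(C)cc4)n3n2)cc1` differs from compound 3 in one place: methyl in place of hydrogen on an aromatic carbon. Among the measured compounds shown here, no measured step matches this change exactly. The two steps that touch the same region of the core, a phenyl for a methyl and a hydrogen for a bromine, were both small, one within the scatter and one only modestly beyond it. With changes of one small group producing so little movement, the expectation for compound 4 in this assay is a step of about a number 0.6 percentage points lower from compound 3 to compound 4 (within the scatter), that is, nothing beyond the scatter. Compound 4 is therefore estimated at 22%, with a likely range from 8% to 38%.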

Compound 4, a percentage reported as inhibition, in the whole organism at one dose (the size of the read-out at that dose, not a potency): 20%
Estimate against measurement, compound 4: 2 percentage points above; measured number inside the range.
By their numbers in this assay, from the lowest: compounds 2, 1, 4 and 3 (each within the scatter of the next, the first and the last beyond it).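

Placing a methyl on an aromatic carbon para to a large group turns phenyl into 4-methylphenyl, and in this assay this gives a number 2.6 percentage points lower from compound 3 to compound 4 (within the scatter) so the added carbon has no readable effect here. The larger swap at the same place on the shared core, 4-methylphenyl in place of methyl, gives a number 6 percentage points higher from compound 1 to compound 4 (within the scatter) which means that compound 1, compound 3 and compound 4 cannot be told apart at this one dose, and methyl, phenyl and 4-methylphenyl all look alike on this read-out. Nothing available explains why these numbers stay so close.

The compounds shown leave open whether a group of a different kind on that phenyl ring, such as an amine, a carboxylic acid or a longer chain like butyl, would move the number beyond the usual scatter. They also leave open whether the methyl would matter at other doses or at other times, since each compound here is represented by one number from one dose and that number is not a potency.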